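Notes on three compounds at the limit and a fourth

This account rests on a few compounds, and the source may have more. Where it says the series, first, only, none or still open, it means among the compounds named here.

Measured so far in a functional assay on T47D cells (Homo sapiens) for cytotoxicity, read by MTT assay, with a stated time of 2 days (on this read-out higher numbers stand for weaker inhibition and lower numbers for stronger inhibition), every value a limit of the assay:
compound 1, `O=c1[nH]c(-c2cccc3ccccc23)nc2ccc(N3CCCCC3)cc12`, > 50000 nM
compound 2, `Cc1ccc2c(=O)[nH]c(-c3cccc(OC(F)(F)F)c3)nc2c1`, > 50000 nM
compound 3, `Cc1ccc2c(=O)[nH]c(-c3cccc(F)c3)nc2c1`, > 50000 nM

Compound 1 stands at the limit of this assay; its value is a limit and not a number. Compound 2 likewise gives only a limit. Compound 3 also gives only a limit. Going by the values given here, the one step between measured compounds, a step that the two limits leave unreadable from compound 2 to compound 3, cannot be read: both of its ends are limits. The whole of the evidence is the limit of > 50000 nM in this assay, at which 3 of the 3 values shown sit, with no numerical value anywhere in the set.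

Compound 4, `Cc1ccc2nc(-c3cccc4ccccc34)[nH]c(=O)c2c1`, differs from compound 1 in one place: methyl in place of piperidin-1-yl on an aromatic carbon. Among the compounds with values here, no measured step bears on this change. Within the data shown here, the only recorded step, a step that the two limits leave unreadable from compound 2 to compound 3, concerns a different position and is unreadable in size. Nothing in the set separates any compound from the others in this assay, so no direction can be drawn from the data.

Compound 4 is expected to sit at or near the limit as well. The step that the limit leaves unreadable from compound 1 to compound 4 is expected to be no more than scatter around an unread position. The estimate for compound 4 is 60000 nM, from 20000 nM to 200000 nM, most probably reported as a limit rather than a number.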

Compound 4, half-maximal inhibitory concentration: > 50000 nM
Compound 4 was reported as a limit; the forecaster's own chance of this, stated with the estimate: 85%; the middle value does not contradict the limit.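

The step between compound 1 and compound 4 cannot be read, and neither can any other step in the set, as both ends of each are limits and not numbers: the limit of > 50000 nM in this assay, at which 4 of the 4 values shown sit.

The compounds shown leave open whether any change on the shared core gives a numerical value in this assay at all.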